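Replacing bromo with hydrogen in compound 2

A few compounds are considered here, and "the series" means these few. Any claim that something is new, unique, unknown or untested is made for them only; others in the source may bear on it.

In an ADME assay on cells (Macrophage) for cytotoxicity, read by resazurin assay, with a stated time of 48 h (a higher number here means that more compound is tolerated, a lower number that less compound is tolerated), compound 1 (`O=C(/C=C/c1c(F)cccc1Cl)c1ccc(OCc2cn(Cc3ccc(Br)cc3)nn2)cc1O`) gives 65800 nM and compound 2 (`O=C(/C=C/c1ccccc1)c1ccc(OCc2cn(Cc3ccc(Br)cc3)nn2)cc1O`) gives 71700 nM, so the two lie within the scatter of each other. Compound 3 (`O=C(/C=C/c1ccccc1)c1ccc(OCc2cn(Cc3ccccc3)nn2)cc1O`) has hydrogen in place of bromo on an aromatic carbon, para to a large group (hydrogen in place of bromo on an aromatic carbon). Among the measured compounds shown here, the only measured step, a 1.1-fold higher number from compound 1 to compound 2 (0.04 log units; within the scatter), lies at a different place and bears on this change only indirectly. It gives no reason to expect a large shift in this assay. The expected step is a 1.1-fold higher number from compound 2 to compound 3 (0.04 log units; within the scatter), with nothing beyond the scatter foreseen. Compound 3 is estimated at 78000 nM, with an expected range of 40000 nM to 150000 nM.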

Compound 3, half-maximal cytotoxic concentration: 80000 nM
Compound 3: the middle estimate sits 1.0-fold (0.01 log units) below what was measured; the measured number falls inside the stated range.
By their numbers in this assay, from the lowest: compounds 1, 2 and 3 (each within the scatter of the next).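

Taking the bromo off the aromatic carbon gives a 1.1-fold higher number from compound 2 to compound 3 (0.05 log units; within the scatter) in this assay and so, unlike the earlier step at a different place, tests this position directly. Within the scatter, 4-bromobenzyl and benzyl cannot be told apart in this assay, so the bromo is not needed for the tolerated level seen with compound 2. Nothing available accounts for this result. Still open, as far as these compounds go, is whether an amine or a carboxylic acid at this position would move the number beyond the scatter.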